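Ester in place of amide at a limit compound

The source may report more compounds than this note shows. Statements on the series, on what has been measured and on what is new or still open speak of the compounds shown alone.

In a functional assay on MCF7 cells (Homo sapiens) for antiproliferative activity, read by MTT assay, with a stated time of 48 h (on this read-out higher numbers stand for weaker inhibition and lower numbers for stronger inhibition), compound 1 `CCn1c(C(=O)NCCN)ccc1C(CC)(CC)c1ccc(OCCC(O)(CC)CC)c(C)c1` gives 670 nM as its value. In this assay compound 2 `C=CCN(C)C(=O)c1ccc(C(CC)(CC)c2ccc(OCCC(O)(CC)CC)c(C)c2)n1CC` gives > 50000 nM which is a limit of the assay and not a number. Going by the values given here, compound 3 `C#CCCOC(=O)c1ccc(C(CC)(CC)c2ccc(OCCC(O)(CC)CC)c(C)c2)n1CC` has (but-3-yn-1-yl)oxy in place of allyl(methyl)amino on a carbonyl carbon as its only change. Among the compounds with values here, the one measured step at this carbonyl is large: an at least 74-fold higher number from compound 1 to compound 2 (1.87 log units; beyond the scatter) and it leaves (2-aminoethyl)amino, which compound 3 also lacks. Little change is therefore expected in this assay with no firm direction, and the number should stay high. The expected step is an at least 1.4-fold lower number from compound 2 to compound 3 (0.15 log units; that floor lies within the scatter) on this reasoning. Compound 3 is estimated at 35000 nM with an expected range of 8000 nM to 80000 nM in this assay.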

Compound 3, half-maximal inhibitory concentration: > 50000 nM
Compound 3 ended at the assay's limit (the forecaster's own chance of this, stated with the estimate: 55%); middle value at least 1.4-fold (0.15 log units) away from the limit.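

A second replacement of (2-aminoethyl)amino on this carbonyl carbon, now an ester rather than an amide, gives an at least 74-fold higher number from compound 1 to compound 3 (1.87 log units; beyond the scatter) in this assay. Compound 3 gives > 50000 nM, which is a limit of the assay and not a number. The step between compound 2 and compound 3 cannot be read, so allyl(methyl)amino and (but-3-yn-1-yl)oxy cannot be ordered: the limit of > 50000 nM in this assay, at which 2 of the 3 values shown sit.

Open, as far as these compounds go, is whether the terminal amine of compound 1 is what matters. A (2-hydroxyethyl)amino group or a carboxylic acid at this carbonyl would test that.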